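From hydroxy to methoxy: compound 1 to compound 4

The compounds below may be only part of what the source reports. "The series", "measured", "known", "first", "only" and "open" are said of these compounds alone.

In an ADME assay on a cell-free system (serum) for metabolic stability (on this read-out lower numbers stand for a shorter-lived compound and higher numbers for a longer-lived compound), compound 1 `CC(C)(C)c1cc(NC(=O)c2ccc(Cl)cc2Cl)ccc1O` gives > 1 h as a limit and not a number. Compound 2 `CC(C)(C)c1cc(NC(=O)c2ccc(Cl)cc2Cl)cc(C(C)(C)C)c1O` gives > 1 h as a limit too. Compound 3 `Cc1cc(NC(=O)c2ccc(Cl)cc2Cl)ccc1O` gives > 1 h as a limit too. Compound 4 `COc1ccc(NC(=O)c2ccc(Cl)cc2Cl)cc1C(C)(C)C` differs from compound 1 by methyl in place of hydrogen on an oxygen on an aromatic ring and the same difference reads hydroxy to methoxy. Among the measured compounds shown here, two measured steps bear on it only loosely, since both fall on an aromatic carbon and not on the oxygen: one is a step that the two limits leave unreadable from compound 1 to compound 2 and the other is a step that the two limits leave unreadable from compound 1 to compound 3 and neither has a readable size. All three values rest on the limit of > 1 h in this assay, at which 3 of the 3 values shown sit, and so offer no size to carry over. No step beyond the usual scatter is therefore expected in this assay and no direction can be given. The estimated step is a step that the limit leaves unreadable from compound 1 to compound 4 and another limit is the likeliest report. For compound 4 the expected value is 2 h with an estimated range from 1 h to 6 h in this measurement.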

Compound 4, half-life: > 1 h
Compound 4 was reported as a limit; the forecaster's own chance of this, stated with the estimate: 75%; the middle value is on the limit's open side.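

No new step can be read between compound 1 and compound 4 in this assay, as each is reported only as a limit: the limit of > 1 h in this assay, at which 4 of the 4 values shown sit. The compounds shown leave open the actual half-life of each compound and whether hydroxy to methoxy shifts it at all.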